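Double-bond geometry and growth inhibition from compound 2

This account rests on a few compounds, and the source may have more. Where it says the series, first, only, none or still open, it means among the compounds named here.

In a functional assay on HL-60 cells (Homo sapiens) for antiproliferative activity (a higher number here means a weaker inhibitor of growth, a lower number a stronger inhibitor of growth), compound 1 `COCCCCCCCCCCCCCCC/C=C1/CC(CO)(COC(=O)C(C)(C)C)OC1=O` gives 3.97 ug/mL. In this assay, compound 2 `CC(C)(C)C(=O)OCC1(CO)C/C(=C\CCCCCCCCCCCCCCC=O)C(=O)O1` is known only by a limit, > 10 ug/mL. The move to compound 3 `CC(C)(C)C(=O)OCC1(CO)C/C(=C/CCCCCCCCCCCCCCC=O)C(=O)O1` keeps the same atoms and bonds: the two compounds have the same atoms and bonds; at least one stereo element is drawn with a configuration in one of them and without one in the other: 1 of 2 stereo elements differ; a double bond is drawn E in compound 2 and Z in compound 3. The only difference is that a double bond is drawn E in compound 2 and Z in compound 3. Among the compounds with values here, no measured step guides this change, and no shift beyond the scatter is expected in this assay, in either direction. The expected size is an estimated step that the limit leaves unreadable from compound 2 to compound 3. Compound 3 is expected at about 12 ug/mL, with an estimated range from 5 ug/mL to 30 ug/mL.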

Compound 3, concentration for 50% growth inhibition: > 10 ug/mL
Compound 3 was reported as a limit (the forecaster's own chance of this, stated with the estimate: 65%); the middle value lies beyond the limit too.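

The step between compound 2 and compound 3 cannot be read, so the double-bond change shows no measurable effect in this assay, since both values are limits: the limit of > 10 ug/mL in this assay, at which 2 of the 3 values shown sit. The comparison is further qualified: the fact that one of compounds 2 and 3 is drawn with a defined configuration and the other without, at the place where they differ. Compound 3 does give a readable step, with formyl in place of methoxymethyl on a saturated chain carbon producing an at least 2.5-fold higher number from compound 1 to compound 3 (0.40 log units; beyond the scatter).

Still open, from the compounds shown here alone, is how far each compound lies past the limit, and whether double-bond geometry matters with methoxymethyl on the chain. Also open, going by these compounds, is how a carboxylic acid or an amine in place of formyl would behave.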